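Benzyl-to-methyl selenium step across two acyl cores

The compounds below may be only part of what the source reports. "The series", "measured", "known", "first", "only" and "open" are said of these compounds alone.

Four selenoureas sharing a diacyl arrangement are compared in a functional assay on K562 cells (Homo sapiens) for cytotoxicity, read by MTT assay, with a stated time of 72 h; a higher number here means a weaker inhibitor of growth, a lower number a stronger inhibitor of growth. Compound 3 `O=C(/N=C(/NC(=O)c1cccs1)[Se]Cc1ccccc1)c1cccs1` carries a benzyl group on selenium and thiophene acyl groups; in this assay compound 3 gives 58500 nM. Compound 1 `C[Se]/C(=N\C(=O)c1cccs1)NC(=O)c1cccs1` is its methyl counterpart. In this assay compound 1 reaches only a limit, > 100000 nM, and no number. The step hydrogen in place of phenyl on a saturated chain carbon bound to a selenium atom therefore reads as an at least 1.7-fold higher number from compound 3 to compound 1 (0.23 log units; that floor lies within the scatter), and its size is only a floor because of the limit of > 100000 nM in this assay, at which 1 of the 3 values shown sits.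

Compound 2 `O=C(/N=C(/NC(=O)c1ccno1)[Se]Cc1ccccc1)c1ccno1` keeps the benzyl group on selenium but carries isoxazole acyl groups; in this assay compound 2 gives 57300 nM, which sits within the scatter of compound 3. The difference between the two cores is not broken down here.

Compound 4 `C[Se]/C(=N\C(=O)c1ccno1)NC(=O)c1ccno1` is the methyl counterpart of compound 2, and the change hydrogen in place of phenyl on a saturated chain carbon bound to a selenium atom is the same change as that from compound 3 to compound 1. Compound 2 starts from 57300 nM. A step of the size seen for compound 3 going to compound 1, an at least 1.7-fold higher number from compound 3 to compound 1 (0.23 log units; that floor lies within the scatter), is expected to carry compound 4 to the same limit. The expected step is a 2.1-fold higher number from compound 2 to compound 4 (0.32 log units; beyond the scatter). Compound 4 is accordingly estimated at 120000 nM, with a range of 60000 nM to 300000 nM, and the most likely outcome is that this assay again reports only a limit for compound 4.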

Compound 4, concentration for total growth inhibition: 45600 nM
Compound 4: middle estimate off by 2.6-fold (0.42 log units), on the high side, outside the stated range (below it).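

In this assay, replacing benzyl with methyl on selenium with the isoxazole acyl groups in place gives a 1.3-fold lower number from compound 2 to compound 4 (0.10 log units; within the scatter), so on this core the phenyl group can go without a change beyond the scatter. Set beside the same change with the thiophene acyl groups, the comparison reads: the same change on two cores in this assay, an at least 1.7-fold higher number (0.23 log units; that floor lies within the scatter) from compound 3 to compound 1 and a 1.3-fold lower number (0.10 log units; within the scatter) from compound 2 to compound 4; the limit leaves it open whether they differ The thiophene step is only a floor, so no size can be carried from that core to the other, and the pair shows neither that the change transfers between cores nor that it depends on the core: the limit of > 100000 nM in this assay, at which 1 of the 4 values shown sits.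

The compounds shown leave open how a longer chain on selenium, or a chain ending in an amine or a carboxylic acid, would read in this assay. They also leave open the actual number for compound 1, whose entry is a limit.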